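This account rests on a few compounds, and the source may have more. Where it says the series, first, only, none or still open, it means among the compounds named here.

Compound 1 `O=C1CCCN1c1cnc(NCc2c(F)ccc3c2CCO3)n2cnnc12` in an ADME assay on microsomes from liver (Homo sapiens) for metabolic stability, read by LC-MS, using NADPH, with stated times of 5 min and 30 min, tested at 1 uM (a higher number here means faster removal of the compound, a lower number slower removal), gives < 3 mL.min-1.g-1, a limit of the assay.
Compound 2 `O=C(Nc1cnc(NCc2c(F)ccc3c2CCO3)n2cnnc12)c1cccnc1` gives < 3 mL.min-1.g-1, again a limit.
Compound 3 `COCCC(=O)Nc1cnc(NCc2c(F)ccc3c2CCO3)n2cnnc12` gives < 3 mL.min-1.g-1, also a limit.

Compound 3 therefore stands at the floor of what the measurement can report, a position it shares with every value shown (the limit of < 3 mL.min-1.g-1 in this assay, at which 3 of the 3 values shown sit). The move to compound 4 `CN(C(=O)c1ccccc1)c1cnc(NCc2c(F)ccc3c2CCO3)n2cnnc12` is benzoyl(methyl)amino in place of ((2-methoxyethyl)carbonyl)amino on an aromatic carbon. Going by the values given here, two measured steps touch the same site, a step that the two limits leave unreadable from compound 1 to compound 3 and a step that the two limits leave unreadable from compound 2 to compound 3, but since both ends of each sit at the limit, neither gives a readable size or direction. With every shown value at the limit, the expectation for compound 4 is that it too stays slow, so the estimated step of a number no lower from compound 3 to compound 4 (the limit leaves the size open) is about none beyond the scatter. Compound 4 is expected to give about 3 mL.min-1.g-1, between 1 mL.min-1.g-1 and 10 mL.min-1.g-1.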

Compound 4, intrinsic clearance in microsomes in the Homo sapiens assay: > 300 mL.min-1.g-1
Compound 4 ended at the assay's limit; the forecaster's own chance of this, stated with the estimate: 50%; middle value at least 100-fold (2.00 log units) from the limit.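

Going by these compounds alone, in the Homo sapiens assay this position is far from indifferent to its substituent, unlike what the earlier compounds could show, since the steps among them cannot be read: an at least 100-fold higher number from compound 3 to compound 4 (2.00 log units; beyond the scatter), an at least 100-fold higher number from compound 2 to compound 4 (2.00 log units; beyond the scatter) and an at least 100-fold higher number from compound 1 to compound 4 (2.00 log units; beyond the scatter). On these data alone, each of these steps joins two limits of the assay, so its true size stays open. In a physicochemical assay for lipophilicity, using the shake flask method, in phosphate buffer, measured as octanol-water partition, with a stated time of 30 min, at pH 7.4 (a higher number here means a more lipophilic compound, a lower number a more polar compound), compound 3 gives 1.4 and compound 4 gives 2.4, so higher lipophilicity may contribute to the faster removal: the measured distribution coefficient of compound 3, 1.4, and of compound 4, 2.4, a number 1.00 log units higher (beyond the scatter)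

The benzoyl(methyl)amino group brings both a methyl group on the amide nitrogen and a benzene ring, and the compounds shown do not separate the two. Plain benzoylamino, without the methyl, and acetyl(methyl)amino, without the ring, would each test one part alone.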